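Trading the Dimethylamino End of Compound 3 for Amino

This account rests on a few compounds, and the source may have more. Where it says the series, first, only, none or still open, it means among the compounds named here.

In a functional assay on HepG2 cells (Homo sapiens), read by MTT assay, with a stated time of 48 h (a lower number here means a stronger inhibitor, a higher number a weaker inhibitor), compound 1 (`CCn1c(C(=O)NCCCN(C)C)ccc1C(CC)(CC)c1ccc(OCC(=O)C(C)(C)C)c(C)c1`) gives 960 nM, compound 2 (`CCN(CC)CCCNC(=O)c1ccc(C(CC)(CC)c2ccc(OCC(=O)C(C)(C)C)c(C)c2)n1CC`) gives 180 nM and compound 3 (`CCn1c(C(=O)NCCCN(C)C)ccc1C(CC)(CC)c1ccc(OCC(O)C(C)(C)C)c(C)c1`) gives 360 nM. The values of compound 3 and compound 2 lie within the usual scatter of each other. Placing 1-hydroxy-2,2-dimethylpropyl where (tert-butyl)carbonyl stood gave a 2.7-fold lower number from compound 1 to compound 3 (0.43 log units; beyond the scatter).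

Compound 4 (`CCn1c(C(=O)NCCN)ccc1C(CC)(CC)c1ccc(OCC(O)C(C)(C)C)c(C)c1`) keeps that hydroxy-bearing group and alters the other end of the molecule: amino in place of (dimethylamino)methyl on a saturated chain carbon, two bonds along the chain from an amide-type nitrogen.

Among the measured compounds shown here, only one measured step touches this end. Diethylamino in place of dimethylamino gave a 5.3-fold lower number from compound 1 to compound 2 (0.73 log units; beyond the scatter), a modest step. That change adds carbon to the amine, whereas the new one removes it, so the opposite direction seems the likelier outcome. For the measured compounds named here, the support is thin, since no measured compound carries an amino end or the shorter chain. The step from the hydroxy change concerns the other end and offers no guide here.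

The expected change is a 2.5-fold higher number from compound 3 to compound 4 (0.40 log units; beyond the scatter), a modest step towards weaker inhibition. For compound 4 the estimated value is 900 nM, with an expected range from 300 nM to 2700 nM.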

Compound 4, half-maximal inhibitory concentration: 176 nM
Compound 4: middle estimate off by 5.1-fold (0.71 log units), on the high side, outside the stated range (below it).
By their numbers in this assay, from the lowest: compounds 4, 2 and 3 (each within the scatter of the next, the first and the last beyond it); then compound 1.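

In this assay the exchange of (dimethylamino)methyl for amino gave a 2.0-fold lower number from compound 3 to compound 4 (0.31 log units; beyond the scatter) and so moved the number towards stronger inhibition, even though this change takes carbon away from the end of the chain. Among the compounds shown here, the only earlier step at this end, the diethylamino exchange, added carbon and gave a 5.3-fold lower number from compound 1 to compound 2 (0.73 log units; beyond the scatter) in the series carrying (tert-butyl)carbonyl, so these two steps show that adding carbon and removing it can both lower the number, and that carbon count alone does not order the values at this end. Nothing measured here accounts for the direction of the new step.

The same difference also reads as 3-(dimethylamino)propyl to 2-aminoethyl, so the shorter chain and the unsubstituted amine arrive together, and the compounds shown leave open which of them carries the step; a 3-aminopropyl or a 2-(dimethylamino)ethyl group in this place would separate the two. Also open is whether diethylamino gives a similar step alongside the 1-hydroxy-2,2-dimethylpropyl group, where only the dimethylamino and amino ends are shown.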